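Series notes: an amino variant of compound 1

The compounds below may be only part of what the source reports. "The series", "measured", "known", "first", "only" and "open" are said of these compounds alone.

Measured so far:
compound 1, `O=c1[nH]cnc2c1c(-c1cc3ccccc3o1)cn2[C@@H]1O[C@H](CO)[C@@H](O)[C@H]1O` — 62700 nM
compound 2, `O=c1[nH]cnc2c1c(-c1cccs1)cn2[C@@H]1O[C@H](CO)[C@@H](O)[C@H]1O` — > 100000 nM
compound 3, `O=c1[nH]cnc2c1c(-c1ccoc1)cn2[C@@H]1O[C@H](CO)[C@@H](O)[C@H]1O` — > 100000 nM

For the measured compounds named here, in an ADME assay on BJ cells (Homo sapiens), read by MTT assay, with a stated time of 72 h (on this read-out higher numbers stand for weaker inhibition and lower numbers for stronger inhibition), compound 1 gives 62700 nM, the only number in the set. For compound 2 the value > 100000 nM is a limit of the assay, not a number. For compound 3 the value > 100000 nM is likewise a limit. Going by the values given here, two of three points therefore sit at the limit of > 100000 nM in this assay, at which 2 of the 3 values shown sit, and compound 1 is the sole compound with a number, standing below that limit.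

The measured steps are an at least 1.5-fold higher number from compound 1 to compound 2 (0.20 log units; that floor lies within the scatter) and an at least 1.5-fold higher number from compound 1 to compound 3 (0.20 log units; that floor lies within the scatter); the remaining pair gives a step that the two limits leave unreadable from compound 2 to compound 3. All three exchange one aryl group on an aromatic carbon of the shared core.

Compound 4, `Nc1nc2c(c(-c3cc4ccccc4o3)cn2[C@@H]2O[C@H](CO)[C@@H](O)[C@H]2O)c(=O)[nH]1`, differs from compound 1 at another place: amino in place of hydrogen on an aromatic carbon. Among the compounds with values here, none of the measured steps touches this position, so none bears on the change directly; the expectation can rest only on compound 1 itself. No step beyond the scatter is expected in either direction, a 1.0-fold lower number from compound 1 to compound 4 (0.02 log units; within the scatter), with a wide range around it. The estimate for compound 4 in this assay is 60000 nM, expected to fall between 20000 nM and 180000 nM.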

Compound 4, half-maximal inhibitory concentration: > 100000 nM
Compound 4 gave a limit, no number; the forecaster's own chance of this, stated with the estimate: 35%; middle value at least 1.6-fold (0.22 log units) from the limit.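

In this assay compound 4 gives > 100000 nM, which is a limit of the assay and not a number. Amino in place of hydrogen on the aromatic carbon between two ring nitrogen atoms, with the 1-benzofuran-2-yl group unchanged, gives an at least 1.5-fold higher number from compound 1 to compound 4 (0.20 log units; that floor lies within the scatter). The earlier compounds differed only in the aryl group, so this is the first read on this position; it shows no stronger inhibition with amino there, and compound 4 now shares the ceiling of the series: the limit of > 100000 nM in this assay, at which 3 of the 4 values shown sit.

The true size of the step stays unread, so it remains open whether amino weakens inhibition beyond the scatter at all, and the compounds shown do not say how the same exchange reads with thiophen-2-yl or furan-3-yl on the shared core. A methylamino group, a dimethylamino group or a chlorine on the same aromatic carbon would show whether this read-out responds to anything else at this position, and only a replacement that yields a number, rather than a limit, could size such a change.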